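The compounds below may be only part of what the source reports. "The series", "measured", "known", "first", "only" and "open" are said of these compounds alone.

Measured so far, in a functional assay on ACHN cells (Homo sapiens) for cytotoxicity, read by MTT assay, with a stated time of 48 h; on this read-out lower numbers stand for stronger inhibition and higher numbers for weaker inhibition:

Compound 1 `COc1ccc2nc(NC(=O)c3cc(-c4ccc(F)cc4)n4nc(-c5ccccc5)cc4n3)sc2c1`: 26300 nM
Compound 2 `COc1ccc(-c2cc(C(=O)Nc3nc4ccc(OC)cc4s3)nc3cc(-c4ccccc4)nn23)cc1`: 38300 nM
Compound 3 `COc1ccc2nc(NC(=O)c3cc(-c4cc(OC)c(OC)c(OC)c4)n4nc(-c5ccccc5)cc4n3)sc2c1`: 5240 nM

Compound 2 has the highest number of the three. Its nearest neighbour is compound 1, with a 1.5-fold higher number from compound 1 to compound 2 (0.16 log units; within the scatter), which is within the scatter. Its furthest is compound 3, with a 7.3-fold lower number from compound 2 to compound 3 (0.86 log units; beyond the scatter); the related step of a 5.0-fold lower number from compound 1 to compound 3 (0.70 log units; beyond the scatter) points the same way.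

Compound 4 `COc1ccc(-c2cc(C(=O)Nc3nc4cc(C)c(C)cc4s3)nc3cc(-c4ccccc4)nn23)cc1` differs from compound 2 in one place: 5,6-dimethyl-1,3-benzothiazol-2-yl in place of 6-methoxy-1,3-benzothiazol-2-yl on an amide-type nitrogen. Every measured step in this set changes the aryl on an aromatic carbon and leaves the 6-methoxy-1,3-benzothiazol-2-yl untouched, so none of them bears on the change in compound 4. Going by the values given here, there is no measured step in this assay that reads on the amide-type nitrogen side. With no guidance either way, the step from compound 2 to compound 4 in this assay is expected to stay within the scatter, as a 1.1-fold lower number from compound 2 to compound 4 (0.04 log units; within the scatter). Compound 4 is accordingly estimated at 35000 nM, with a range of 12000 nM to 100000 nM.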

Compound 4, half-maximal inhibitory concentration: 22400 nM
For compound 4 the middle estimate is 1.6-fold (0.19 log units) above the measured one; low and high end bracket the measured number.
By their numbers in this assay, from the lowest: compound 3; then compounds 4, 1 and 2 (each within the scatter of the next).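

In this assay, the one change shown on the amide-type nitrogen gives a 1.7-fold lower number from compound 2 to compound 4 (0.23 log units; within the scatter) and so leaves 5,6-dimethyl-1,3-benzothiazol-2-yl and 6-methoxy-1,3-benzothiazol-2-yl indistinguishable in the setting of compound 2. Going by these compounds alone, the earlier steps read only on the aryl on an aromatic carbon, so this is the first reading for the other side of the amide, and this exchange does not register beyond the scatter. Nothing available accounts for this result.

The compounds shown leave open whether the same exchange stays within the scatter when 3,4,5-trimethoxyphenyl replaces 4-methoxyphenyl, as in compound 3. They also leave open whether an amine or a carboxylic acid on the 1,3-benzothiazol-2-yl would move the number beyond the scatter.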